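The source may hold more compounds than are shown below. What is called first, only, known or untested is meant among the compounds shown, and "the series" means these compounds.

Among the compounds with values here, in a functional assay on HT-29 cells (Homo sapiens) for antiproliferative activity, read by MTT assay, with a stated time of 24 h (on this read-out higher numbers stand for weaker inhibition and lower numbers for stronger inhibition), only one compound of this small series has so far given a true number: compound 1 `COc1ccc(C(=O)/C=C/c2ccc(N(C)C)cc2)c2c1C=CC(C)(C)O2` reads 1870 nM. Compound 2 `COc1ccc(/C=C/C(=O)c2ccc(OC)c3c2OC(C)(C)C=C3)cn1` reads > 10000 nM, which is a limit of the assay and not a number. Compound 3 `COc1ccc(C(=O)/C=C/c2cccc(O)c2)c2c1C=CC(C)(C)O2` reads > 10000 nM, and this too is only a limit. The upper end of the series is thus set by the limit of > 10000 nM in this assay, at which 2 of the 3 values shown sit.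

Compound 4 `COc1ccc(C(=O)/C=C/c2ccc(O)c(Br)c2)c2c1C=CC(C)(C)O2` keeps the core of compound 3 and alters only the aryl group on a double-bonded chain carbon bound to a double-bonded chain carbon, with 3-bromo-4-hydroxyphenyl in place of 3-hydroxyphenyl on a double-bonded chain carbon bound to a double-bonded chain carbon.

Two measured steps change the group at this same place: an at least 5.3-fold higher number from compound 1 to compound 2 (0.72 log units; beyond the scatter) and an at least 5.3-fold higher number from compound 1 to compound 3 (0.72 log units; beyond the scatter). Both show that this group matters in this assay, though neither tests bromine, and the third, a step that the two limits leave unreadable from compound 2 to compound 3, cannot be read. Compound 1 at 1870 nM shows how low a number this series has reached, so only a moderate gain is expected. Another reading at the limit remains quite possible for compound 4. The expected change is an at least 1.6-fold lower number from compound 3 to compound 4 (0.22 log units; that floor lies within the scatter). For compound 4 the estimated value is 6000 nM, within an expected range of 1800 nM to 12000 nM.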

Compound 4, half-maximal inhibitory concentration: > 10000 nM
Compound 4 gave a limit, no number; the forecaster's own chance of this, stated with the estimate: 45%; at least 1.6-fold (0.22 log units) between middle value and limit.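

With 3-bromo-4-hydroxyphenyl on a double-bonded chain carbon bound to a double-bonded chain carbon, compound 4 joins compound 3 at the limit, so a hydroxyphenyl group that also carries bromine gives no true number in this assay either. Among the four groups tried at this place, 4-(dimethylamino)phenyl in compound 1 remains the only one to give a number, and bromine does not close the gap, with an at least 5.3-fold higher number from compound 1 to compound 4 (0.72 log units; beyond the scatter). The steps from compound 2 and from compound 3 to compound 4 cannot be read, and the series now gathers at its upper end: the limit of > 10000 nM in this assay, at which 3 of the 4 values shown sit.

Going by these compounds, how far compound 3 and compound 4 lie apart stays open, and so does whether bromine alone does anything at this place, as the names of the two groups also differ in where the hydroxy group stands. On these data alone, it is equally open whether the number of compound 1 depends on the dimethylamino group itself, which a primary amine or a pyrrolidine in its stead would test.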